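The compounds below may be only part of what the source reports. "The series", "measured", "known", "first", "only" and "open" are said of these compounds alone.

In an assay on mitochondria from L6 cells (Rattus norvegicus) for activation, with a stated time of 90 min (a lower number here means that less compound is needed, a higher number that more compound is needed for the effect), compound 1 `Cc1ccccc1Nc1nc2nonc2nc1Nc1ccccc1C` gives 2300 nM and compound 3 `FC(F)(F)c1ccccc1Nc1nc2nonc2nc1Nc1ccccc1C(F)(F)F` gives 1000 nM. Compound 2 `COc1cccc(Nc2nc3nonc3nc2Nc2cccc(OC)c2)c1` stands apart from both: in this assay compound 2 reaches only > 100000 nM, which is a limit of the assay and not a number, so the value sits at the limit of > 100000 nM in this assay, at which 1 of the 3 values shown sits. Compound 4 `COc1cccc(Nc2nc3nonc3nc2Nc2ccccc2F)c1` has not yet been measured in this assay. It differs from compound 2 in one place: 2-fluorophenyl in place of 3-methoxyphenyl on a nitrogen on an aromatic ring. Compound 4 keeps one (3-methoxyphenyl)amino arm of compound 2 and carries a (2-fluorophenyl)amino arm in place of the other. Since compound 2 gives only a limit, the size of the step cannot be fixed from the numbers, but the values of compound 1 and compound 3 show that the shared core can reach the micromolar range. The step from compound 2 to compound 4 is therefore expected to run toward a lower number, an at least 5.0-fold lower number from compound 2 to compound 4 (0.69 log units; beyond the scatter), beyond the scatter. Compound 4 is estimated at 20000 nM in this assay, within 3000 nM to 100000 nM.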

Compound 4, half-maximal effective concentration: 830 nM
Compound 4: middle estimate off by 24-fold (1.38 log units), on the high side; the whole stated range lies above it.
By their numbers in this assay, from the lowest: compounds 4 and 3 (each within the scatter of the next); then compound 1. At a limit, above all of these: compound 2.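

In this assay this one change gives an at least 120-fold lower number from compound 2 to compound 4 (2.08 log units; beyond the scatter), so a (3-methoxyphenyl)amino arm on the shared core does not by itself hold a compound at the limit. Compound 4 alone among the compounds shown carries two different arms, and replacing just one arm of compound 2 is enough to leave the limit. The value of compound 2 is a limit and not a number, so the step has a bound and no fixed size: the limit of > 100000 nM in this assay, at which 1 of the 4 values shown sits.

The compounds shown leave open whether the change in number comes from the loss of 3-methoxyphenyl or from the entry of 2-fluorophenyl. They also leave open how a plain phenyl or a 2-chlorophenyl would read on that nitrogen, and how an amine or a carboxylic acid would read on the remaining arm.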